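The source may report more compounds than this note shows. Statements on the series, on what has been measured and on what is new or still open speak of the compounds shown alone.

Measured compounds:
compound 1 `COC(=O)[C@@]1(C)CCC=C2[C@@H]1CC[C@@H](C)[C@]2(C)Cc1c[nH]c2ccc(OC)cc12` gives 1300 nM in a functional assay on SW1573 cells (Homo sapiens) for inhibition, read by sulforhodamine B assay, with a stated time of 48 h; on this read-out higher numbers stand for weaker inhibition of growth and lower numbers for stronger inhibition of growth;
compound 2 `COC(=O)[C@@]1(C)CCC=C2[C@@H]1CC[C@@H](C)[C@]2(C)Cc1c(C)[nH]c2ccccc12` gives 14000 nM in this assay;
compound 3 `COC(=O)[C@@]1(C)CCC=C2[C@@H]1CC[C@@H](C)[C@]2(C)Cc1c(C)[nH]c2ccc(Cl)cc12` gives 14000 nM in this assay.

On these numbers compound 3 is level with compound 2 at the digits shown, the two together giving the highest values of the three, while compound 1 gives a lower number, beyond the scatter. Going by the values given here, the single measured step that changes the same aromatic position, no change at the digits printed from compound 2 to compound 3 (within the scatter), shows no change beyond the scatter. Compound 4 `COC(=O)[C@@]1(C)CCC=C2[C@@H]1CC[C@@H](C)[C@]2(C)Cc1c(C)[nH]c2ccc(OC)cc12` is compound 3 with methoxy in place of chloro on an aromatic carbon. Among the compounds with values here, compound 1 also carries a methoxy at this position, but it lacks the methyl on the five-membered ring that compounds 2, 3 and 4 share, so its lower value cannot be traced to the methoxy alone; no measured step separates the two changes.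

Because no change at the digits printed from compound 2 to compound 3 (within the scatter) shows that the aromatic substituent at this position left the number unchanged, compound 4 is expected to stay close to compound 3, with a wide range that admits a move toward compound 1. The estimate for compound 4 in this assay is 9000 nM, between 2500 nM and 30000 nM, meaning an expected step of a 1.6-fold lower number from compound 3 to compound 4 (0.19 log units; within the scatter).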

Compound 4, concentration for 50% growth inhibition: 15000 nM
Estimate against measurement, compound 4: 1.7-fold (0.22 log units) below; the range from low to high includes it.
By their numbers in this assay, from the lowest: compound 1; then compounds 2, 3 and 4 (each within the scatter of the next).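

In this assay, with the methyl on the five-membered ring kept in place, the aromatic position that is meta to a fused ring and para to a fused ring took methoxy without any shift beyond the scatter, whether set against chloro, a 1.1-fold higher number from compound 3 to compound 4 (0.03 log units; within the scatter), or against hydrogen, a 1.1-fold higher number from compound 2 to compound 4 (0.03 log units; within the scatter), so hydrogen, chloro and methoxy at this position cannot be told apart here. Compound 4 also supplies the comparison that was missing, since it shares the methoxy with compound 1 and differs only by methyl in place of hydrogen on the five-membered ring, and a 12-fold higher number from compound 1 to compound 4 (1.06 log units; beyond the scatter) is a large step beyond the scatter, which ties the gap to that ring position and not to the methoxy. Nothing available explains why this one change matters so much while the other does not.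

Going by these compounds alone, whether the methyl carries the same penalty with chloro or hydrogen on the six-membered ring remains open, as the only pair that isolates it has methoxy on both sides. Also open, on these data alone, is how an ethyl group at the five-membered ring position, or an amine or a carboxylic acid on the six-membered ring, would fare in this assay.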